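Notes on a Tryptophan 2,3-dioxygenase Inhibitor Series

The source may report more compounds than this note shows. Statements on the series, on what has been measured and on what is new or still open speak of the compounds shown alone.

Measured so far:
compound 1 `Oc1ccc(CNc2cc(C(F)(F)F)cc3[nH]ncc23)cc1`, 91%
compound 2 `O=[N+]([O-])c1ccc(CNc2cc(Br)cc3[nH]ncc23)cc1`, 93%

In an assay for inhibition of Tryptophan 2,3-dioxygenase (Homo sapiens), with stated times of 10 min and 60 min, tested at 100 uM (a lower number here means a weaker effect, a higher number a stronger effect of the compound at the concentration tested), compound 2 gives 93%, and compound 1 gives 91%; the two numbers lie within the scatter of each other, so neither stands apart. Within the data shown here, no step between measured compounds is available.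

Compound 3 `O=[N+]([O-])c1ccc(CNc2cc(C(F)(F)F)cc3[nH]ncc23)cc1` is unmeasured. It differs from compound 2 as follows: trifluoromethyl in place of bromo on an aromatic carbon.

Given that compound 1 carries trifluoromethyl and gives 91%, the step of a number 1 percentage points lower from compound 2 to compound 3 (within the scatter) is expected to stay within the scatter, with no clear direction.

The estimate for compound 3 in this assay is 92%, between 82% and 98%.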

Compound 3, a percentage reported as inhibition, at one concentration (the size of the read-out at that concentration, not a potency): 64%
Compound 3: middle estimate off by 28 percentage points, on the high side; measured number outside the range, below it.
By their numbers in this assay, from the lowest: compound 3; then compounds 1 and 2 (each within the scatter of the next).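

In this assay, the bromo position is not interchangeable with trifluoromethyl: with nitro kept, trifluoromethyl in place of bromo gives a number 29 percentage points lower from compound 2 to compound 3 (beyond the scatter). With trifluoromethyl kept, nitro in place of hydroxy gives a number 27 percentage points lower from compound 1 to compound 3 (beyond the scatter). Among these three compounds, neither group alone goes with the low number, only the two together in compound 3.

Hydroxy paired with bromo remains open, as does an amine or a carboxylic acid in place of nitro. No evidence here bears on the reason for these steps.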